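Vitamin D receptor agonists: one amide side chain exchanged

This account rests on a few compounds, and the source may have more. Where it says the series, first, only, none or still open, it means among the compounds named here.

compound 2 `CCN(CC)CCCNC(=O)c1ccc(C(CC)(CC)c2ccc(C#CC(O)(CC)CC)c(C)c2)n1CC` — 68.9 nM
compound 1 `CCn1c(C(=O)NCCC(=O)OC)ccc1C(CC)(CC)c1ccc(C#CC(O)(CC)CC)c(C)c1` — > 50 nM

Of the compounds shown here, two of the shared core have been tested in an assay on cells for agonist activity at vitamin D3 receptor (Homo sapiens), read by microscopy; on this read-out lower numbers stand for an effect already at smaller amounts and higher numbers for an effect only at larger amounts of compound. Compound 2 `CCN(CC)CCCNC(=O)c1ccc(C(CC)(CC)c2ccc(C#CC(O)(CC)CC)c(C)c2)n1CC` gives 68.9 nM. Compound 1 `CCn1c(C(=O)NCCC(=O)OC)ccc1C(CC)(CC)c1ccc(C#CC(O)(CC)CC)c(C)c1` gives only a limit of the assay, > 50 nM. Among the values shown, compound 2 holds the only number; the other value is a limit (the limit of > 50 nM in this assay, at which 1 of the 2 values shown sits). Within the data shown here, the single step between the two, a step that the limit leaves unreadable from compound 1 to compound 2, therefore has no readable size.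

Compound 3 `CCn1c(C(=O)NCc2ccc(OC)cc2)ccc1C(CC)(CC)c1ccc(C#CC(O)(CC)CC)c(C)c1` remains to be measured. Its change from compound 2 reads (4-methoxyphenyl in place of 2-(diethylamino)ethyl on a saturated chain carbon bound to an amide-type nitrogen). No measured step contains this exchange, and the one step shown cannot be read, so the expectation rests on compound 2 alone. The expected step is a 1.0-fold higher number from compound 2 to compound 3 (0.01 log units; within the scatter), held within wide bounds. The estimate for compound 3 is 70 nM, expected to fall between 20 nM and 300 nM.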

Compound 3, half-maximal effective concentration: > 50 nM
Compound 3 ended at the assay's limit; the forecaster's own chance of this, stated with the estimate: 30%; the middle value does not contradict the limit.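

No step among compound 1, compound 2 and compound 3 can be read, because only compound 2 holds a number: the limit of > 50 nM in this assay, at which 2 of the 3 values shown sit.

The compounds shown leave open where compound 1 and compound 3 truly stand against compound 2 in this assay, and so what exchanging the amide side chain does to the read-out.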